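The source may hold more compounds than are shown below. What is called first, only, known or untested is meant among the compounds shown, and "the series" means these compounds.

Of the compounds shown here, two of a shared core have been measured in a functional assay on HEK293 cells for agonist activity at Glucose-dependent insulinotropic receptor (Homo sapiens), read by cAMP accumulation, with a stated time of 30 min; on this read-out lower numbers stand for an effect already at smaller amounts and higher numbers for an effect only at larger amounts of compound. Compound 1 `CC1(COC(=O)N2CC3COCC(C2)C3Oc2ncnc(Nc3ccc(C#N)cc3Cl)c2F)COC1` gives 188 nM, while compound 2 `CC1(OC(=O)N2CC3COCC(C2)C3Oc2ncnc(Oc3ccccc3F)c2F)CC1` gives 26 nM, the lower of the two numbers and, beyond the scatter, apart from compound 1. Compound 3 `CC1(OC(=O)N2CC3COCC(C2)C3Oc2ncnc(Nc3ccc(F)cc3F)c2F)CC1` differs from compound 2 in one place: (2,4-difluorophenyl)amino in place of 2-fluorophenoxy on an aromatic carbon. For the measured compounds named here, no measured pair shows this exact change, and the only other amino-linked compound, compound 1, also differs elsewhere. A moderate rise is therefore expected, a 2.3-fold higher number from compound 2 to compound 3 (0.36 log units; beyond the scatter), with compound 3 estimated at 60 nM within a range of 20 nM to 200 nM.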

Compound 3, half-maximal effective concentration: 15 nM
The estimate for compound 3 lay 4.0-fold (0.60 log units) above the measured number; measured number outside the range, below it.
By their numbers in this assay, from the lowest: compounds 3 and 2 (each within the scatter of the next); then compound 1.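

Replacing 2-fluorophenoxy with (2,4-difluorophenyl)amino on this aromatic carbon gives a 1.7-fold lower number from compound 2 to compound 3 (0.24 log units; within the scatter), so the two compounds cannot be told apart. With the rest of the molecule unchanged, this position accepts an amino link and a second ring fluorine together as well as it accepts the oxygen link. No separate measurement bears on this result. Going by these compounds, the link and the added fluorine changed in the same step, so their separate contributions remain open. A (2-fluorophenyl)amino group would separate them, and a saturated ring such as piperidine would test whether the aromatic ring is needed here.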